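Compound 3 to compound 4: exchange on the sulfonyl sulfur

The source may hold more compounds than are shown below. What is called first, only, known or untested is meant among the compounds shown, and "the series" means these compounds.

Values so far in an ADME assay on microsomes from liver (Rattus norvegicus) for metabolic stability, read by LC-MS, using NADPH, with a stated time of 30 min, tested at 0.1 uM (on this read-out higher numbers stand for a more stable compound and lower numbers for a less stable compound), are as follows:
compound 1 `O=S(=O)(NCC1COC1)c1cccc(-c2ccc3nccc(-c4ccncc4)c3n2)c1` gives 8%
compound 2 `CS(=O)(=O)Nc1cccc(-c2ccc3nccc(-c4ccncc4)c3n2)c1` gives 49%
compound 3 `O=S(=O)(c1cccc(-c2ccc3nccc(-c4ccncc4)c3n2)c1)N1CC[C@H](O)C1` gives 10%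

Compound 3 stands level with compound 1 and well short of compound 2 (see a number 39 percentage points lower from compound 2 to compound 3 (beyond the scatter)). The next structure is compound 4 `C[C@@H]1CN(S(=O)(=O)c2cccc(-c3ccc4nccc(-c5ccncc5)c4n3)c2)C[C@H](C)N1` and the change is 3,5-dimethylpiperazin-1-yl in place of 3-hydroxypyrrolidin-1-yl on a sulfonyl sulfur with 3,5-dimethylpiperazin-1-yl in place of 3-hydroxypyrrolidin-1-yl on a sulfonyl sulfur. Going by the values given here, the closest precedent is the other exchange on that sulfur, a number 2 percentage points higher from compound 1 to compound 3 (within the scatter) and thus a small step. The large step of a number 41 percentage points higher from compound 1 to compound 2 (beyond the scatter) replaces the whole sulfonyl-bearing group with methanesulfonamido. The other large step, already cited, is a number 39 percentage points lower from compound 2 to compound 3 (beyond the scatter) and is an exchange of the same kind in reverse. Nothing of that kind happens here. These three compounds offer no measured case of the 3,5-dimethylpiperazin-1-yl group, so the expectation remains loose and leans upward only in its range. The estimate therefore means a number 1 percentage points higher from compound 3 to compound 4 (within the scatter) in this assay and no expected step beyond the scatter. Compound 4 is expected at 11% (estimated range 3% to 28%).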

Compound 4, percent of the compound remaining: 36%
The estimate for compound 4 lay 25 percentage points below the measured number, and the stated range ends below it.
By their numbers in this assay, from the lowest: compounds 1 and 3 (each within the scatter of the next); then compound 4; then compound 2.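

In this assay, the group on the sulfonyl sulfur turns out to matter: 3,5-dimethylpiperazin-1-yl in place of 3-hydroxypyrrolidin-1-yl gives a clear gain (a number 26 percentage points higher from compound 3 to compound 4 (beyond the scatter)), and in place of ((oxetan-3-yl)methyl)amino it gives a gain of similar size (a number 28 percentage points higher from compound 1 to compound 4 (beyond the scatter)), whereas the earlier exchange on that sulfur stayed within the scatter. A sulfonyl-linked compound therefore need not sit at the low end of the series, although the (3,5-dimethylpiperazin-1-yl)sulfonyl group still falls short of methanesulfonamido (a number 13 percentage points lower from compound 2 to compound 4 (beyond the scatter)). Nothing available here accounts for these steps.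

The exchange changes ring size, the second ring nitrogen, the hydroxyl and the methyl groups all at once, so their contributions stay unseparated. An unsubstituted piperazin-1-yl or a morpholin-4-yl on the sulfonyl sulfur would begin to pull them apart.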